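The source may hold more compounds than are shown below. What is called first, only, known or untested is meant among the compounds shown, and "the series" means these compounds.

Working notes on the cytotoxicity series.

Compound 1 `C/C=C/C(=O)Nc1cccc(Oc2nc(Nc3ccn(C)n3)nc3c2CSCC3)c1`, compound 2 `CC/C=C/C(=O)Nc1cccc(Oc2nc(Nc3ccn(C)n3)nc3c2CSCC3)c1` and compound 3 `CC/C=C/C(=O)Nc1cccc(Oc2nc(Nc3cccc(OC)c3)nc3c2CSCC3)c1` share a core built around a thiopyrano-fused pyrimidine ether; compound 4 `CCC/C=C/C(=O)Nc1cccc(Oc2nc(Nc3cccc(OC)c3)nc3c2CSCC3)c1` is the fourth member and remains to be measured. In an ADME assay on L02 cells (Homo sapiens) for cytotoxicity, read by MTT assay, with a stated time of 72 h (on this read-out lower numbers stand for stronger inhibition and higher numbers for weaker inhibition), compound 1 gives > 50000 nM, which is a limit of the assay and not a number. In this assay compound 2 likewise gives > 50000 nM, again a limit. In this assay compound 3 gives > 50000 nM, also a limit. The step that the two limits leave unreadable from compound 1 to compound 2 therefore cannot be sized, and the same holds for a step that the two limits leave unreadable from compound 2 to compound 3. The change from compound 1 to compound 2 is methyl in place of hydrogen on a saturated chain carbon bound to a double-bonded chain carbon. The difference between the core of compound 1 and the core of compound 3 is not broken down here.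

Compound 4 arises from compound 3 by methyl in place of hydrogen on a saturated chain carbon, two bonds along the chain from a double-bonded chain carbon. This is the same kind of change as from compound 1 to compound 2, though the place differs: in the earlier pair the carbon is bound to a double-bonded chain carbon, whereas here it sits two bonds along the chain from a double-bonded chain carbon. Because all three known values sit at the limit of > 50000 nM in this assay, at which 3 of the 3 values shown sit, no shift in cytotoxicity has been resolved for any change in the set. The step from compound 3 to compound 4 in this assay is expected to be a step that the limit leaves unreadable from compound 3 to compound 4, a flat step placed beside the unreadable earlier one, resting on compound 3 at > 50000 nM and on the absence of any resolved movement across the series. Compound 4 is accordingly expected to give about 100000 nM in this assay, most likely reported only as a limit, with the range 50000 nM to 300000 nM estimated for it.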

Compound 4, half-maximal inhibitory concentration: > 50000 nM
Compound 4 ended at the assay's limit (the forecaster's own chance of this, stated with the estimate: 85%); the middle value lies beyond the limit too.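

In this assay compound 4 gives > 50000 nM as a limit of the assay and not a number. For the compounds shown here, compound 3 and compound 4 both stand at a limit, so no step between them can be read. All the values shown rest on one limit: the limit of > 50000 nM in this assay, at which 4 of the 4 values shown sit.

The compounds shown leave open how far any of the four lies from that limit, and whether any change in the chain or on the nitrogen shifts cytotoxicity at all.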